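Swapping Methyl for Chloro on the Amide-Nitrogen Aryl Ring

This account rests on a few compounds, and the source may have more. Where it says the series, first, only, none or still open, it means among the compounds named here.

Measured compounds:
- compound 1 `COC(=O)c1nnn([C@@H]2C(=O)N(c3ccc(C)cc3)[C@@H]2/C=C/c2ccccc2)c1C(=O)OC`: "not determined" (no result reported)
- compound 2 `O=C1[C@@H](n2cc(-c3ccccc3)nn2)[C@@H](/C=C/c2ccccc2)N1c1ccccc1`: 10%
- compound 3 `O=C1[C@@H](n2cc(-c3ccccc3)nn2)[C@@H](/C=C/c2ccccc2)N1C1CCCCC1`: 76.8%

All compounds share a core in which a four-membered ring bearing a carbonyl carries a triazole on one side and a styryl chain on the other. In a functional assay on KB cells (Homo sapiens) for inhibition, tested at 10 uM (on this read-out higher numbers stand for more inhibition of growth at the one concentration tested and lower numbers for less inhibition of growth), compound 1 has no number: its result was not reported. Compound 2 and compound 3 differ only in the group on the amide-type nitrogen, and there a number 66.8 percentage points higher from compound 2 to compound 3 (beyond the scatter), a large step.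

Compound 4 `COC(=O)c1nnn([C@@H]2C(=O)N(c3ccc(Cl)cc3)[C@@H]2/C=C/c2ccccc2)c1C(=O)OC` is the unmeasured compound. It differs from compound 1 by a single change, (chloro in place of methyl on an aromatic carbon); cut one bond further out, this reads 4-methylphenyl to 4-chlorophenyl. Within the data shown here, no measured step covers this change: the only step known, from compound 2 to compound 3, concerns a different position and a different pair of groups, so it does not bear on it. Compound 1 itself has no value to start from. Among the measured compounds the one carrying a phenyl on the amide-type nitrogen, compound 2, gives 10%, and compound 4 also carries an aryl group there, although its triazole differs.

On that loose basis compound 4 is expected to show modest inhibition in this assay, estimated at 20% with a wide range from 0% to 60%.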

Compound 4, percent growth inhibition at one concentration: 19.5%
Beside the measured number, compound 4's estimate is 0.5 percentage points above it; low and high end bracket the measured number.
By their numbers in this assay, from the lowest: compounds 2 and 4 (each within the scatter of the next); then compound 3.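

In this assay, among these compounds, compound 4 gives 19.5% and compound 1 stands as "not determined" (no result reported) so no step from methyl to chloro can be read between these two compounds. The compounds shown leave open how chloro in place of methyl changes growth inhibition on this shared core. No supporting data bear on the value of compound 4.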